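The compounds below may be only part of what the source reports. "The series", "measured", "known", "first", "only" and "open" are said of these compounds alone.

Measured in a functional assay on HL-60 cells (Homo sapiens) for inhibition, read by MTT assay, with a stated time of 72 h; on this read-out higher numbers stand for weaker inhibition and lower numbers for stronger inhibition:
Compound 1 `Cc1ccc(C)c(N2CCN(C(=O)c3oc(C)nc3-c3ccc(F)cc3)CC2)c1`: 358 nM
Compound 2 `COc1cccc(N2CCN(C(=O)c3oc(C)nc3-c3ccccc3F)CC2)c1`: 56.1 nM
Compound 3 `COc1ccc(Cl)cc1N1CCN(C(=O)c2oc(C)nc2-c2ccccc2F)CC1`: 153 nM
Compound 4 `Cc1ccc(C)c(N2CCN(C(=O)c3oc(C)nc3-c3ccccc3F)CC2)c1`: not yet measured

Compound 3 holds the middle place of the three numbers, with compound 1 higher and compound 2 lower. Compound 4 differs from it by 2,5-dimethylphenyl in place of 5-chloro-2-methoxyphenyl on an amine nitrogen in a ring. Among the measured compounds shown here, only one measured step changes this group, a 2.7-fold higher number from compound 2 to compound 3 (0.44 log units; beyond the scatter), and it is modest. Compound 4 differs elsewhere from compound 1, which also carries 2,5-dimethylphenyl, so compound 1 with 358 nM is only a loose guide. It does suggest a lean towards a higher number in this assay. The expected change is small, an estimated 1.3-fold higher number from compound 3 to compound 4 (0.12 log units; within the scatter). For compound 4 the estimated value is 200 nM, with an expected range from 80 nM to 480 nM.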

Compound 4, half-maximal inhibitory concentration: 319 nM
The estimate for compound 4 lay 1.6-fold (0.20 log units) below the measured number; the measured number falls inside the stated range.
By their numbers in this assay, from the lowest: compound 2; then compound 3; then compounds 4 and 1 (each within the scatter of the next).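

In this assay, with the 2-fluorophenyl group held constant, 2,5-dimethylphenyl on the amine nitrogen gives the higher number against both earlier groups at this position: 5-chloro-2-methoxyphenyl (a 2.1-fold higher number from compound 3 to compound 4 (0.32 log units; beyond the scatter)) and 3-methoxyphenyl (a 5.7-fold higher number from compound 2 to compound 4 (0.75 log units; beyond the scatter)). With 2,5-dimethylphenyl in place, exchanging 4-fluorophenyl for 2-fluorophenyl on the aromatic carbon stays within the scatter (a 1.1-fold lower number from compound 1 to compound 4 (0.05 log units; within the scatter)). No measurement offered here explains these differences. The compounds shown leave open how an unsubstituted phenyl or a pyridine ring on the amine nitrogen would read. They also leave open whether the fluorine position remains equally silent alongside 3-methoxyphenyl.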